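The compounds below may be only part of what the source reports. "The series", "measured", "known", "first", "only" and "open" are said of these compounds alone.

Measured in an ADME assay on LLC-MK2 cells (Macaca mulatta) for cytotoxicity, read by spectrophotometry and crystal violet staining, with a stated time of 4 days; a higher number here means that more compound is tolerated, a lower number that less compound is tolerated:
- compound 1 `CC(C)n1ncc2c(C(=O)Nc3ncccn3)cc(-c3cccs3)nc21`: 75000 nM
- compound 2 `CNS(=O)(=O)c1cccc(NC(=O)c2cc(-c3cccs3)nc3c2cnn3C(C)C)c1`: 25000 nM
- compound 3 `CC(C)n1ncc2c(C(=O)Nc3ccc(F)cn3)cc(-c3cccs3)nc21`: > 200000 nM

Compound 3 stands at the limit of > 200000 nM in this assay, at which 1 of the 3 values shown sits, so it has a limit and not a number.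

Compound 4 `CC(C)n1ncc2c(C(=O)Nc3cccc(S(N)(=O)=O)c3)cc(-c3cccs3)nc21` differs from it by 3-sulfamoylphenyl in place of 5-fluoropyridin-2-yl on an amide-type nitrogen, with 3-sulfamoylphenyl in place of 5-fluoropyridin-2-yl on an amide-type nitrogen. Within the data shown here, the one measured step at this place is an at least 2.6-fold higher number from compound 1 to compound 3 (0.42 log units; beyond the scatter), and it shows that a swap here can go beyond the scatter. The measured compound that looks nearest to compound 4 at this place is compound 2 at 25000 nM. A lower number is therefore expected in this assay, and the expected move is an at least 5.0-fold lower number from compound 3 to compound 4 (0.69 log units; beyond the scatter). Compound 4 is estimated at 40000 nM, with an expected range of 15000 nM to 120000 nM.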

Compound 4, half-maximal cytotoxic concentration: 25000 nM
Compound 4: the middle estimate sits 1.6-fold (0.20 log units) above what was measured, and the stated range covers the measured number.
By their numbers in this assay, from the lowest: compounds 2 and 4 (each within the scatter of the next); then compound 1. At a limit, above all of these: compound 3.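

In this assay, 3-sulfamoylphenyl on the amide-type nitrogen gives an at least 8.0-fold lower number from compound 3 to compound 4 (0.90 log units; beyond the scatter) when it replaces 5-fluoropyridin-2-yl, and a 3.0-fold lower number from compound 1 to compound 4 (0.48 log units; beyond the scatter) when it replaces pyrimidin-2-yl. The first of these steps starts from a limit and not from a number: the limit of > 200000 nM in this assay, at which 1 of the 4 values shown sits. On the sulfonamide nitrogen, hydrogen in place of methyl gives no change at the digits printed from compound 2 to compound 4 (within the scatter), so the two groups are not told apart there.

The compounds shown leave open what a longer chain on the sulfonamide nitrogen would do to this number. They also leave open what a carboxylic acid in place of the sulfonamide would do.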